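Benzyloxy ring substituents in a benzimidazole thiourea series

This account rests on a few compounds, and the source may have more. Where it says the series, first, only, none or still open, it means among the compounds named here.

Compound 1, `Cc1ccc(NC(=S)NC(=O)c2ccc(OCc3ccccc3)cc2)cc1-c1nc2ccccc2[nH]1`, gives 28800 nM in a functional assay on HT-29 cells (Homo sapiens) for inhibition, read by MTT assay, with a stated time of 48 h; a higher number here means a weaker inhibitor, a lower number a stronger inhibitor.
Compound 2, `Cc1ccc(NC(=S)NC(=O)c2ccc(OCc3cccc(C(F)(F)F)c3)cc2)cc1-c1nc2ccccc2[nH]1`, gives 8200 nM.
Compound 3, `Cc1ccc(NC(=S)NC(=O)c2ccc(OCc3ccc(Cl)cc3Cl)cc2)cc1-c1nc2ccccc2[nH]1`, gives 11600 nM.

On these three numbers compound 3 stands second highest. Its nearest neighbour is compound 2: a 1.4-fold higher number from compound 2 to compound 3 (0.15 log units; within the scatter). Its furthest is compound 1: a 2.5-fold lower number from compound 1 to compound 3 (0.39 log units; beyond the scatter). Compound 4, `Cc1ccc(NC(=S)NC(=O)c2ccc(OCc3ccc(F)cc3)cc2)cc1-c1nc2ccccc2[nH]1`, differs from compound 3 in one place: 4-fluorophenyl in place of 2,4-dichlorophenyl on a saturated chain carbon bound to an oxygen on an aromatic ring.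

Two measured steps speak to this change. Both substituted benzyl rings gave lower numbers than the unsubstituted ring of compound 1, as the step to compound 3 above shows and as a 3.5-fold lower number from compound 1 to compound 2 (0.55 log units; beyond the scatter) shows for the trifluoromethyl ring; the two substituted rings themselves sit within the scatter of each other. Compound 4 carries a single fluorine where compound 3 carries two chlorines, a smaller halogen load than either compound 2 or compound 3, so its number is expected to fall between that of compound 1 and that of compound 3, and the expected step of a 1.5-fold higher number from compound 3 to compound 4 (0.17 log units; within the scatter) is a modest rise. Compound 4 is therefore estimated at 17000 nM in this assay, with a range from 7000 nM to 40000 nM.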

Compound 4, half-maximal inhibitory concentration: 1910 nM
Compound 4: the middle estimate sits 8.9-fold (0.95 log units) above what was measured; the measured number lies below the stated range.
By their numbers in this assay, from the lowest: compound 4; then compounds 2 and 3 (each within the scatter of the next); then compound 1.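

In this assay, the ring on the saturated chain carbon bound to an oxygen on an aromatic ring proves more sensitive than compounds 2 and 3 had indicated. The largest step among these compounds is a 15-fold lower number from compound 1 to compound 4 (1.18 log units; beyond the scatter). The 4-fluorophenyl ring also separates compound 4 from both earlier substituted rings, with a 6.1-fold lower number from compound 3 to compound 4 (0.78 log units; beyond the scatter) and a 4.3-fold lower number from compound 2 to compound 4 (0.63 log units; beyond the scatter), although compounds 2 and 3 themselves remain within the scatter of each other; a lighter substituent load therefore does not by itself track with a lower number, and compound 1, with its bare phenyl ring and the highest number of the four, goes against any such reading. Nothing measured here accounts for the behaviour of the 4-fluorophenyl ring.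

The compounds shown leave open whether the lower number of compound 4 belongs to fluorine as such or to a single substituent at that place on the ring, a question that a 4-chlorophenyl or a 2,4-difluorophenyl ring would address. They also leave open whether a 4-methoxyphenyl or a 4-aminophenyl ring would keep the number of compound 4 in this cell assay.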